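Replacing a tetrazole with an isopropyl amide in an EP3 antagonist series

A few compounds are considered here, and "the series" means these few. Any claim that something is new, unique, unknown or untested is made for them only; others in the source may bear on it.

Measured compounds:
Compound 1, `CC(C)C(Nc1nnc[nH]1)c1ccc(-c2ccc3cccc(F)c3c2)[nH]c1=O`, gives 185 nM in a functional assay on CHO cells for antagonist activity at prostaglandin E2 receptor EP3 subtype (Homo sapiens), read by cAMP accumulation; a lower number here means a stronger inhibitor, a higher number a weaker inhibitor.
Compound 2, `CC(C)C(Cc1nnn[nH]1)c1ccc(-c2ccc3cccc(F)c3c2)[nH]c1=O`, gives 134 nM in this assay.

Compound 2 has the lowest of the two numbers in this assay, but its nearest neighbour, compound 1, lies close: a 1.4-fold lower number from compound 1 to compound 2 (0.14 log units; within the scatter), so the two cannot be ranked.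

Compound 3, `CC(C)NC(=O)CC(c1ccc(-c2ccc3cccc(F)c3c2)[nH]c1=O)C(C)C`, is not yet measured. It differs from compound 2 by isopropylcarbamoyl in place of 1H-tetrazol-5-yl on a saturated chain carbon, two bonds along the chain from an aromatic carbon. For the measured compounds named here, the only measured step, a 1.4-fold lower number from compound 1 to compound 2 (0.14 log units; within the scatter), swapped one small ring for another at the same part of the chain and barely moved the number; it gives no direct precedent for an open-chain amide entering in place of a ring. With only that step to lean on, a change not far beyond the scatter is expected in this assay, in either direction, though the shown data do not settle which.

Compound 3 is therefore estimated at 250 nM, within 80 nM to 800 nM, a step of a 1.9-fold higher number from compound 2 to compound 3 (0.27 log units; within the scatter).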

Compound 3, half-maximal inhibitory concentration: 15 nM
Compound 3: the middle estimate sits 17-fold (1.22 log units) above what was measured; the measured number lies below the stated range.
By their numbers in this assay, from the lowest: compound 3; then compounds 2 and 1 (each within the scatter of the next).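

In this assay, this end of the chain proves far more responsive than the first two compounds suggested: isopropylcarbamoyl in place of 1H-tetrazol-5-yl gives an 8.9-fold lower number from compound 2 to compound 3 (0.95 log units; beyond the scatter). The (isopropylcarbamoyl)methyl group in place of (4H-1,2,4-triazol-3-yl)amino gives a 12-fold lower number from compound 1 to compound 3 (1.09 log units; beyond the scatter), so at this place a group with no ring gives a lower number than either ring-bearing group, while those two remain within the scatter of each other. Nothing measured here explains why the open-chain amide does better.

On these data alone, it remains open whether the amide itself or its isopropyl part accounts for the change. A primary amide, a methyl amide or a carboxylic acid at the same place would help separate the two.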